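A few compounds are considered here, and "the series" means these few. Any claim that something is new, unique, unknown or untested is made for them only; others in the source may bear on it.

Of the compounds shown here, three built on a shared core have been tested in a functional assay on PC-3 cells (Homo sapiens) for cytotoxicity, read by MTT assay; on this read-out lower numbers stand for stronger inhibition and higher numbers for weaker inhibition. Compound 1 `COc1ccc(/C=C/C(=O)c2sc(Nc3ccc(Cl)c(Cl)c3)nc2C)cc1` gives only a limit, > 25000 nM. Compound 3 `Cc1ccccc1Nc1nc(C)c(C(=O)/C=C/c2ccccc2)s1` likewise gives only a limit, > 25000 nM. For the measured compounds named here, compound 2 `COc1cc(/C=C/C(=O)c2sc(Nc3ccc(Cl)c(Cl)c3)nc2C)cc(OC)c1OC` gives the only measured number, 19300 nM, and so stands alone among the three. The two other values rest at the limit of > 25000 nM in this assay, at which 2 of the 3 values shown sit. Compound 4 `COc1cc(/C=C/C(=O)c2sc(Nc3ccccc3)nc2C)cc(OC)c1OC` has not yet been measured. It differs from compound 2 by phenyl in place of 3,4-dichlorophenyl on a nitrogen on an aromatic ring. Going by the values given here, no step between two measured compounds is available to anchor this change, so the expectation rests on the single number for compound 2. Compound 4 is expected to come out weaker, by a step of a 1.6-fold higher number from compound 2 to compound 4 (0.19 log units; within the scatter) that may well carry it back to the limit. The estimate for compound 4 is 30000 nM, with a range from 12000 nM to 70000 nM.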

Compound 4, half-maximal inhibitory concentration: > 25000 nM
Compound 4: no number, only a limit (the forecaster's own chance of this, stated with the estimate: 55%); the middle value lies beyond the limit too.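

For the compounds shown here, this is the first step at this position, on a nitrogen on an aromatic ring: in this assay, phenyl in place of 3,4-dichlorophenyl gives an at least 1.2-fold higher number from compound 2 to compound 4 (0.11 log units; that floor lies within the scatter). That floor alone does not show that the chlorine atoms matter. The true size of the step stays unknown because compound 4 gives only a limit, > 25000 nM, and the evidence here is: the limit of > 25000 nM in this assay, at which 3 of the 4 values shown sit.

Still open, as far as these compounds go, is whether any group on this nitrogen, such as a pyridine ring or a benzyl group, would give a clear number well under that limit.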